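Replacing the aryl group with an amide-linked thiophene

A few compounds are considered here, and "the series" means these few. Any claim that something is new, unique, unknown or untested is made for them only; others in the source may bear on it.

Measured so far:
Compound 1, `Cc1nn(-c2ncnc3nc[nH]c23)c2c1C(c1ccc(F)cc1Cl)CC(=O)N2`: 9 nM
Compound 2, `Cc1nn(-c2ncnc3nc[nH]c23)c2c1C(OCc1ccc(C(C)C)cc1)CC(=O)N2`: 5 nM

In a functional assay on HEK293 cells for agonist activity at G-protein coupled receptor 39 (Homo sapiens), read by scintillation proximity assay and inositol phosphate accumulation, with a stated time of 75 min, in the presence of a further agent that is not named here (a higher number here means that more compound is needed for the effect, a lower number that less compound is needed), compound 1 gives 9 nM, and compound 2 gives 5 nM. The two values sit within the usual scatter of each other, so neither compound can be placed above the other on this evidence.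

Compound 3, `Cc1nn(-c2ncnc3nc[nH]c23)c2c1C(NC(=O)Cc1cccs1)CC(=O)N2`, is the next compound. It differs from compound 1 in one place: (((thiophen-2-yl)methyl)carbonyl)amino in place of 2-chloro-4-fluorophenyl on a saturated ring carbon. Compound 2 shows that the shared core tolerates a group attached through a linking atom at this carbon, since compound 2 gives 5 nM. Nothing measured, however, tells how an amide at this carbon behaves, so a modest loss is expected: the step of a 3.3-fold higher number from compound 1 to compound 3 (0.52 log units; beyond the scatter) is estimated to lie somewhat beyond the scatter toward a higher number, and compound 3 is expected to give about 30 nM, within 5 nM to 200 nM.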

Compound 3, half-maximal effective concentration: 3 nM
Compound 3: middle estimate off by 10-fold (1.00 log units), on the high side; the measured number lies below the stated range.
By their numbers in this assay, from the lowest: compounds 3, 2 and 1 (each within the scatter of the next, the first and the last beyond it).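

In this assay, putting (((thiophen-2-yl)methyl)carbonyl)amino in place of 2-chloro-4-fluorophenyl on this saturated ring carbon gives a 3.0-fold lower number from compound 1 to compound 3 (0.48 log units; beyond the scatter). The carbon therefore accepts an amide-linked group, and a six-membered aromatic ring of carbon only is not needed there for a low number. The entering group also brings a hydrogen-bond donor and hydrogen-bond acceptors that the group it replaces lacks, but no measurement here links either feature to the lower number, or otherwise accounts for the change.

The compounds shown cannot separate the contribution of the amide from that of the thiophene, so it remains open whether a phenyl ring would serve in place of the thiophene. Also open, going by these compounds, is how this position would respond to a methyl group in place of the amide hydrogen, or to a longer chain between the carbonyl and the ring.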